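This account rests on a few compounds, and the source may have more. Where it says the series, first, only, none or still open, it means among the compounds named here.

Among the three compounds measured so far, compound 1 `CC(/C=C/CC(C)CCCC(C)C)=C\C(=O)OC(C)(C)C` gives the highest number: in a physicochemical assay for lipophilicity (on this read-out higher numbers stand for higher lipophilicity and lower numbers for lower lipophilicity), compound 1 gives 7.56. Compound 3 `CCOC(=O)/C=C(C)/C=C/CC(C)CCC(SCC)C(C)C` comes nearest, as in this assay compound 3 gives 6.9, which is beyond the scatter below compound 1. Compound 2 `COC(C)(C)CCCC(C)C/C=C/C(C)=C/C(=O)OC(C)(C)C` lies furthest away, since in this assay compound 2 gives 6.36. Among the compounds with values here, the one step between compounds that differ in a single place is a number 1.20 log units lower from compound 1 to compound 2 (beyond the scatter), a large drop that comes from a methoxy in place of hydrogen on a saturated chain carbon bound to three saturated chain carbons.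

Compound 4 `CC(/C=C/CC(C)CCCC(C)C)=C\C(=O)c1ccccc1` has not been measured yet. It differs from compound 1 in one place: phenyl in place of tert-butoxy on a carbonyl carbon. Within the data shown here, no measured step shows this kind of swap, phenyl in place of tert-butoxy on a carbonyl carbon, so the step from compound 1 to compound 2 does not bear on it directly. The group that leaves carries one hydrogen-bond acceptor while the phenyl that enters carries none, and the phenyl brings one more heavy atom; on balance a step of about a number 0.16 log units lower from compound 1 to compound 4 (within the scatter) is expected, close to none beyond the scatter. The estimate for compound 4 in this assay is therefore 7.4, with a range from 6.8 to 8.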

Compound 4, partition coefficient: 7.26
The estimate for compound 4 lay 0.14 log units above the measured number; the measured number falls inside the stated range.
By their numbers in this assay, from the lowest: compound 2; then compound 3; then compounds 4 and 1 (each within the scatter of the next).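

In this assay, the swap of tert-butoxy for phenyl on the carbonyl carbon gives a number 0.30 log units lower from compound 1 to compound 4 (within the scatter) on this read-out, so compound 1 and compound 4 cannot be told apart. Within the data shown here, this is the first look at a change at this end of the molecule, and it shows that an ester carrying tert-butoxy and a ketone carrying an all-carbon aromatic ring can sit within the usual scatter of each other, unlike the only earlier single-place change, on a saturated chain carbon, which gave a number 1.20 log units lower from compound 1 to compound 2 (beyond the scatter) and lay beyond it. Nothing at hand offers an explanation for this result.

Going by these compounds, whether other groups on the same carbonyl carbon, such as an amine that would turn it into an amide, a methoxy or a pyridine ring, would also stay this close to compound 1 remains open. So does whether methoxy in place of hydrogen on the saturated chain carbon bound to three saturated chain carbons would give a step of similar size on the core of compound 4.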